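Swapping Methyl for Methoxy on the Shared Core

The compounds below may be only part of what the source reports. "The series", "measured", "known", "first", "only" and "open" are said of these compounds alone.

compound 1 `COCc1cc(OC)c(-c2cccc3c(N(CC4CCOCC4)CC4CC4)c(SC)nn23)c(OC)c1` gives 30 nM
compound 2 `COCc1cc(OC)c(-c2cccc3c(N(CC4CCOCC4)CC4CC4)c(C)nn23)c(OC)c1` gives 50 nM

Both were tested in a functional assay on HEK293 cells for antagonist activity at corticotropin-releasing factor receptor 1 (Homo sapiens), read by fluorescence and cAMP accumulation, with a stated time of 30 min; on this read-out higher numbers stand for weaker inhibition and lower numbers for stronger inhibition. Compound 2 holds the higher of the two numbers shown, but the one measured step, a 1.7-fold higher number from compound 1 to compound 2 (0.22 log units; within the scatter), lies within the scatter, so the two compounds cannot be ordered. Compound 3 `COCc1cc(OC)c(-c2cccc3c(N(CC4CCOCC4)CC4CC4)c(OC)nn23)c(OC)c1` has not yet been measured. It differs from compound 2 in one place: methoxy in place of methyl on an aromatic carbon. Among the measured compounds shown here, the only step touching this position, methyl in place of methylsulfanyl, stayed within the scatter, so in this assay the expected step is no change at the digits printed from compound 2 to compound 3 (within the scatter), none beyond the scatter. Compound 3 is therefore estimated at 50 nM, within a range from 20 nM to 130 nM.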

Compound 3, half-maximal inhibitory concentration: 110 nM
Estimate against measurement, compound 3: 2.2-fold (0.34 log units) below, within the range that was stated.
By their numbers in this assay, from the lowest: compounds 1 and 2 (each within the scatter of the next); then compound 3.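

The position does respond to what it carries: methoxy gives a 2.2-fold higher number from compound 2 to compound 3 (0.34 log units; beyond the scatter) and, set against methylsulfanyl, a 3.7-fold higher number from compound 1 to compound 3 (0.56 log units; beyond the scatter) while the swap between methyl and methylsulfanyl alone stayed within the scatter. Among these three groups, then, methoxy alone separates from another group, and it does so toward weaker inhibition. No supporting measurement is available to explain this. Still open, going by these compounds, is whether an amine, a chlorine atom or a longer chain on this aromatic carbon would bring the number down or push it further up.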